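The compounds below may be only part of what the source reports. "The series", "measured", "known", "first", "only" and "open" are said of these compounds alone.

Of the compounds shown here, three sharing one core have been tested in a functional assay on HeLa cells (Homo sapiens) for antiproliferative activity, read by sulforhodamine B assay, with a stated time of 48 h; on this read-out higher numbers stand for weaker inhibition and lower numbers for stronger inhibition. Compound 1 `CC(=O)NS(=O)(=O)c1ccc(N/C(S)=N\c2ccnc3cc(C(F)(F)F)ccc23)cc1` gives 37600 nM and stands lowest of the two numbers recorded. Going by the values given here, compound 3 `O=S(=O)(Nc1nccs1)c1ccc(N/C(S)=N\c2ccnc3cc(C(F)(F)F)ccc23)cc1` gives 95200 nM, and the only single-site step among the measured compounds, a 2.5-fold higher number from compound 1 to compound 3 (0.40 log units; beyond the scatter), is a modest weakening. Compound 2 `Cc1noc(NS(=O)(=O)c2ccc(N/C(S)=N\c3ccnc4cc(C(F)(F)F)ccc34)cc2)c1C`, which carries a different heteroaryl group on the same sulfonamide nitrogen, was reported as "not active" (no number reported).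

Compound 4 `Cc1cc(C)nc(NS(=O)(=O)c2ccc(N/C(S)=N\c3ccnc4cc(C(F)(F)F)ccc34)cc2)n1` differs from compound 1 by 4,6-dimethylpyrimidin-2-yl in place of acetyl on a sulfonamide nitrogen. The step from compound 1 to compound 3 bears on this change most directly, since there too an aromatic heterocycle replaced acetyl on the sulfonamide nitrogen, and it weakened inhibition modestly. The outcome for compound 2 shows that such a replacement can also remove measurable activity altogether. A weakening of similar or somewhat larger size is therefore expected, a 2.4-fold higher number from compound 1 to compound 4 (0.38 log units; beyond the scatter), with a real chance that no number is obtained. Compound 4 is expected to give about 90000 nM, within a range from 40000 nM to 250000 nM.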

Compound 4, half-maximal inhibitory concentration: 33000 nM
Compound 4: the middle estimate sits 2.7-fold (0.44 log units) above what was measured, and the stated range ends above it.
By their numbers in this assay, from the lowest: compounds 4 and 1 (each within the scatter of the next); then compound 3.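

In this assay, putting 4,6-dimethylpyrimidin-2-yl in place of acetyl on the sulfonamide nitrogen gives a 1.1-fold lower number from compound 1 to compound 4 (0.06 log units; within the scatter) and so shows that an aromatic ring at this position need not weaken inhibition. The two ring-bearing groups with numbers also differ from each other, with a 2.9-fold lower number from compound 3 to compound 4 (0.46 log units; beyond the scatter) as the result, so the weakening seen with 1,3-thiazol-2-yl does not hold for both measured aromatic rings. Nothing measured here explains why these groups behave as they do.

Any steps to compound 2 cannot be read, as it has no number. On these data alone, it remains open whether a plain pyrimidin-2-yl ring without the two methyl groups, or a sulfonamide nitrogen carrying only hydrogen, would match compound 1 and compound 4.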